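The compounds below may be only part of what the source reports. "The series", "measured", "known", "first", "only" and "open" are said of these compounds alone.

Working notes on the series.

Compound 1 `CC1CCN(C2CCN(S(=O)(=O)c3ccc(-c4ccccc4F)cc3)CC2)CC1` gives 5 nM in a functional assay on DLD-1 cells (Homo sapiens) for antiproliferative activity, read by CellTiter-Glo, with a stated time of 72 h; on this read-out higher numbers stand for weaker inhibition and lower numbers for stronger inhibition. Compound 2 `CC1CCN(C2CCN(S(=O)(=O)c3ccc(-c4ccccc4)cc3)CC2)CC1` differs from it by hydrogen in place of fluoro on an aromatic carbon and gives 258 nM in this assay, so that a 52-fold higher number from compound 1 to compound 2 (1.71 log units; beyond the scatter). Compound 3 `Cc1cc(C)c(S(=O)(=O)N2CCC(N3CCC(Cc4ccccc4F)CC3)CC2)c(C)c1` sits on a different core; how its core differs from that of compound 1 is not broken down here, and in this assay compound 3 gives 74 nM. Compound 4 `Cc1cc(C)c(S(=O)(=O)N2CCC(N3CCC(Cc4ccccc4)CC3)CC2)c(C)c1` is not yet measured; it differs from compound 3 by hydrogen in place of fluoro on an aromatic carbon, the same change as that between compound 1 and compound 2, made at a place described in the same terms. Among the compounds with values here, with only one earlier instance of this change, the expectation for compound 4 rests on compound 1 and compound 2 alone, where a 52-fold higher number from compound 1 to compound 2 (1.71 log units; beyond the scatter) was a large loss. Compound 4 is therefore expected to give a weaker number than compound 3, a step of about a 20-fold higher number from compound 3 to compound 4 (1.31 log units; beyond the scatter), estimated at 1500 nM with a range from 350 nM to 6500 nM.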

Compound 4, half-maximal inhibitory concentration: 3.5 nM
Compound 4: the middle estimate sits 430-fold (2.63 log units) above what was measured, and the stated range ends above it.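

In this assay hydrogen in place of fluoro on an aromatic carbon gives a 21-fold lower number from compound 3 to compound 4 (1.33 log units; beyond the scatter) and so runs opposite to the earlier step. The effect of this change therefore does not carry from the core of compound 1 to the core of compound 3: the same change on two cores in this assay, a 52-fold higher number (1.71 log units; beyond the scatter) from compound 1 to compound 2 and a 21-fold lower number (1.33 log units; beyond the scatter) from compound 3 to compound 4, 1100-fold (3.04 log units) apart, beyond the scatter of two such steps

These two pairs show that the direction of the step can reverse between cores, but they do not show which feature of the cores governs it, and they set no rule for any further core.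

On these data alone, it remains open whether chloro, methoxy or an amine in place of fluoro would follow the step seen on the core of compound 1 or that seen on the core of compound 3. The compounds shown also include no pair linking the two cores by a single change.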